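Pyrrolidinyl in Place of Isobutyl: Cytotoxicity Outlook

The compounds below may be only part of what the source reports. "The series", "measured", "known", "first", "only" and "open" are said of these compounds alone.

Measured so far:
compound 1 `CC(C)n1nc(C(=O)N[C@H]2COc3ccccc3N(C)C2=S)nc1Cc1ccccc1` — > 100000 nM (a limit of the test)
compound 2 `CC(C)Cn1nc(C(=O)N[C@H]2COc3ccccc3N(C)C2=S)nc1Cc1ccccc1` — > 100000 nM (a limit of the test)

In a toxicity assay on HT-29 cells (Homo sapiens) for cytotoxicity (on this read-out lower numbers stand for higher toxicity in this test and higher numbers for lower toxicity in this test), compound 1 gives > 100000 nM, which is a limit of the test rather than a number. In this assay compound 2 likewise gives > 100000 nM, again a limit and not a number. The change from compound 1 to compound 2 is a step that the two limits leave unreadable from compound 1 to compound 2, so its size cannot be read. Both values sit at the limit of > 100000 nM in this assay, at which 2 of the 2 values shown sit. Compound 3 `CN1C(=S)[C@@H](NC(=O)c2nc(Cc3ccccc3)n(C3CCNC3)n2)COc2ccccc21` differs from compound 2 by pyrrolidin-3-yl in place of isobutyl on an aromatic nitrogen. Among the measured compounds shown here, no measured step bears on a pyrrolidin-3-yl on this aromatic nitrogen, and the one measured step gives no readable size, so no shift beyond the scatter is expected in this assay. Compound 3 is therefore expected to show 100000 nM, with a range from 30000 nM to 300000 nM. The estimated step is a number no higher from compound 2 to compound 3 (the limit leaves the size open), and the result is expected most likely to be reported again only as a limit.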

Compound 3, half-maximal cytotoxic concentration: > 100000 nM
Compound 3: no number, only a limit (the forecaster's own chance of this, stated with the estimate: 75%); the middle value sits exactly at the limit.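

No step can be read among compound 1, compound 2 and compound 3 in this assay, as each value is only a limit: the limit of > 100000 nM in this assay, at which 3 of the 3 values shown sit.

The compounds shown leave open whether isopropyl, isobutyl and pyrrolidin-3-yl on the aromatic nitrogen differ at all in this assay.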